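The source may report more compounds than this note shows. Statements on the series, on what has been measured and on what is new or still open speak of the compounds shown alone.

Series notes. Within the data shown here, compound 2 `COc1cc(-c2nn(-c3cccc(NC(=O)Nc4cc(C(F)(F)F)cc(C(F)(F)F)c4)c3)cc2-c2ccncc2)ccc1Cl` gives the lowest of the three numbers so far in a functional assay on KM12 cells (Homo sapiens) for inhibition, read by sulforhodamine B assay, with a stated time of 48 h (on this read-out lower numbers stand for stronger inhibition of growth and higher numbers for weaker inhibition of growth), at 531 nM. Compound 3 `COc1cc(-c2nn(-c3cccc(NC(=O)Nc4cccc(C(F)(F)F)c4)c3)cc2-c2ccncc2)ccc1Cl` sits nearest, with 573 nM in this assay, and the step of a 1.1-fold higher number from compound 2 to compound 3 (0.03 log units; within the scatter) lies within the scatter, so the two cannot be ordered. Compound 1 `O=C(Nc1cccc(-n2cc(-c3ccncc3)c(-c3ccc(Cl)c(O)c3)n2)c1)Nc1cccc(C(F)(F)F)c1` is furthest, at 1330 nM in this assay. Compound 4 `O=C(Nc1cccc(-n2cc(-c3ccncc3)c(-c3ccc(Cl)c(O)c3)n2)c1)Nc1cc(C(F)(F)F)cc(C(F)(F)F)c1` has not yet been measured in this assay. It differs from compound 2 by hydrogen in place of methyl on an oxygen on an aromatic ring. Among the measured compounds shown here, one measured step bears on this directly: a 2.3-fold lower number from compound 1 to compound 3 (0.37 log units; beyond the scatter), which is the same change run the other way, on the pair lacking the second trifluoromethyl. The step of a 1.1-fold higher number from compound 2 to compound 3 (0.03 log units; within the scatter) shows that the extra trifluoromethyl carried by compound 2 and compound 4 does not move the number beyond the scatter, so the change on the oxygen can be read across from the pair of compound 1 and compound 3. Taken together, a modest rise in the number is expected for compound 4 in this assay, roughly reversing what the methyl brought. The expected step is a 2.3-fold higher number from compound 2 to compound 4 (0.36 log units; beyond the scatter). Compound 4 is therefore estimated at 1230 nM in this assay, with a range from 600 nM to 2500 nM.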

Compound 4, concentration for 50% growth inhibition: 506 nM
Beside the measured number, compound 4's estimate is 2.4-fold (0.39 log units) above it; measured number below the stated range.
By their numbers in this assay, from the lowest: compounds 4, 2 and 3 (each within the scatter of the next); then compound 1.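

In this assay, methoxy to hydroxy does not register on the compounds with the second trifluoromethyl, giving a 1.0-fold lower number from compound 2 to compound 4 (0.02 log units; within the scatter), so the step seen earlier on the pair with one trifluoromethyl does not carry over as a fixed increment, although the two readings of this change cannot be firmly told apart: the same change on two cores in this assay, a 2.3-fold lower number (0.37 log units; beyond the scatter) from compound 1 to compound 3 and a 1.0-fold higher number (0.02 log units; within the scatter) from compound 4 to compound 2, 2.4-fold (0.39 log units) apart, within the scatter of two such steps

Trifluoromethyl in place of hydrogen on an aromatic carbon, which did not register on the methoxy pair, now gives a 2.6-fold lower number from compound 1 to compound 4 (0.42 log units; beyond the scatter) on the hydroxy pair, and here too the two readings stay close enough that the difference remains unproven: the same change on two cores in this assay, a 1.1-fold higher number (0.03 log units; within the scatter) from compound 2 to compound 3 and a 2.6-fold higher number (0.42 log units; beyond the scatter) from compound 4 to compound 1, 2.4-fold (0.39 log units) apart, within the scatter of two such steps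

Of the four combinations of these two changes, only compound 1 departs from the rest, which hints that the two places do not act independently, but four compounds cannot settle this.

As far as these compounds go, it remains open whether the oxygen carries a larger group as readily, such as an ethoxy or a longer chain, or whether an amine can stand in place of the hydroxy. From the compounds shown here alone, it is also open whether a nitrile in place of the second trifluoromethyl would leave the number unmoved on both the methoxy and the hydroxy compounds.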